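Removing a fluoro from a weakly cytotoxic urea

This account rests on a few compounds, and the source may have more. Where it says the series, first, only, none or still open, it means among the compounds named here.

Compound 1 `CSc1ccc(NC(=O)Nc2cc(C)nc3ccccc23)cc1` and compound 2 `Cc1cc(NC(=O)Nc2ccc(F)c(F)c2)c2ccccc2n1` reach only the limit of an ADME assay on BJ cells (Homo sapiens) for cytotoxicity, with a stated time of 72 h; a lower number here means that less compound is needed, a higher number that more compound is needed for the effect. For compound 1 this limit is > 25000 nM. For compound 2 the limit is > 25000 nM. Compound 3 `COc1ccc(NC(=O)Nc2cc(C)nc3ccccc23)cc1F`, in this assay, gives 26000 nM, the only actual number among the three compounds shown. The step from compound 2 to compound 3, a step that the limit leaves unreadable from compound 2 to compound 3, cannot be sized because of the limit of > 25000 nM in this assay, at which 2 of the 3 values shown sit. Compound 4 `COc1ccc(NC(=O)Nc2cc(C)nc3ccccc23)cc1` differs from compound 3 by hydrogen in place of fluoro on an aromatic carbon. Among the measured compounds shown here, no measured step bears directly on this change, so no shift beyond the scatter in this assay is expected, and compound 4 is estimated to sit near the limit. The expected step from compound 3 to compound 4 is a 1.2-fold higher number from compound 3 to compound 4 (0.06 log units; within the scatter), giving an estimate for compound 4 of 30000 nM, within 15000 nM to 60000 nM.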

Compound 4, half-maximal effective concentration: > 25000 nM
Compound 4: no number, only a limit (the forecaster's own chance of this, stated with the estimate: 60%); the middle value is on the limit's open side.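

Neither the step to compound 4 from compound 3 nor the step to compound 4 from compound 1 can be read, because of one obstacle: the limit of > 25000 nM in this assay, at which 3 of the 4 values shown sit.

From the compounds shown here alone, how far hydrogen in place of fluoro, or methoxy in place of methylsulfanyl, moves the number in this assay stays open.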